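Moving the Methoxy Group on the Amide Aryl Ring

The source may hold more compounds than are shown below. What is called first, only, known or untested is meant among the compounds shown, and "the series" means these compounds.

Measured compounds:
Compound 1 `CCOC(=O)c1c(O)c2cccnc2n(-c2ccccc2)c1=O`: 23.5%
Compound 2 `COc1ccc(NC(=O)c2c(O)c3cccnc3n(-c3ccccc3)c2=O)cc1`: 0.3%

In a functional assay on the whole organism for inhibition, with Rattus norvegicus as the target, read by paw edema, at a dose of 100 mg/kg by the oral route (a higher number here means more inhibition at the dose given (going by the name of the read-out), a lower number less inhibition), compound 1 gives 23.5%, while compound 2 gives 0.3%. For the measured compounds named here, compound 2 therefore stands lowest of the two numbers known. Going by the values given here, the single measured step, a number 23.2 percentage points lower from compound 1 to compound 2 (beyond the scatter), came from putting (4-methoxyphenyl)amino in place of ethoxy on a carbonyl carbon, a change of a different kind from the one now considered.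

Compound 3 `COc1cccc(NC(=O)c2c(O)c3cccnc3n(-c3ccccc3)c2=O)c1` differs from compound 2 only in where the methoxy group sits: 3-methoxyphenyl in place of 4-methoxyphenyl on an amide-type nitrogen. Among the compounds with values here, no measured step moves a substituent around this aryl ring, so the step of a number 23.2 percentage points lower from compound 1 to compound 2 (beyond the scatter) bears on it only indirectly, by showing that this amide series sits near the bottom of the scale. With nothing pointing either way, the expected change is a number 4.7 percentage points higher from compound 2 to compound 3 (within the scatter), that is, none beyond the scatter. Compound 3 is estimated at 5%, with a range from 0% to 20%.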

Compound 3, a percentage reported as inhibition, in the whole organism at one dose (the size of the read-out at that dose, not a potency): 5.7%
For compound 3 the middle estimate is 0.7 percentage points below the measured one, and the stated range covers the measured number.
By their numbers in this assay, from the lowest: compounds 2 and 3 (each within the scatter of the next); then compound 1.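

In this assay, moving the methoxy group on the aryl ring, with 3-methoxyphenyl in place of 4-methoxyphenyl on the amide-type nitrogen, gives a number 5.4 percentage points higher from compound 2 to compound 3 (within the scatter) and so the two placings cannot be told apart. Putting (3-methoxyphenyl)amino in place of ethoxy on the carbonyl carbon gives a number 17.8 percentage points lower from compound 1 to compound 3 (beyond the scatter) and so both methoxy-bearing amides stand clearly below compound 1, whichever of the two placings the methoxy group takes. Nothing available explains why the ethoxy compound and these amides differ in this way.

Still open, from the compounds shown here alone, is whether a chlorine atom, a hydroxyl group or a carboxylic acid on this aryl ring would bring the number closer to that of compound 1. Going by these compounds, it is also open whether a plain butyl chain on the amide nitrogen, with no aryl ring at all, would read like these amides.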